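The compounds below may be only part of what the source reports. "The series", "measured", "known", "first", "only" and "open" are said of these compounds alone.

The series shares one core, seen in compound 2 `N#Cc1c[nH]c2ncnc(N)c12`, which carries a nitrile. Compound 3 `NC(=S)c1c[nH]c2ncnc(N)c12` and compound 1 `Cc1cccc(Cn2cc(C(=N)S)c3c(N)ncnc32)c1` complete the measured set. In a functional assay on KB cells (Homo sapiens) for cytotoxicity (a lower number here means a stronger inhibitor, a higher number a weaker inhibitor), compound 2 gives 18000 nM, compound 3 gives 25000 nM and compound 1 gives 30000 nM; the three numbers lie within the scatter of one another, so none stands apart. Within the data shown here, the only single step, a 1.4-fold higher number from compound 2 to compound 3 (0.14 log units; within the scatter), concerns the aromatic carbon rather than the ring nitrogen. Compound 4 `C=CCn1cc(C#N)c2c(N)ncnc21` differs from compound 2 by allyl in place of hydrogen on an aromatic nitrogen. Nothing measured touches that nitrogen directly; compound 1, which bears a group there, sits where the others do. He therefore expects for compound 4 a value of 20000 nM (range 8000 nM to 50000 nM), a step of a 1.1-fold higher number from compound 2 to compound 4 (0.05 log units; within the scatter) within the scatter.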

Compound 4, half-maximal inhibitory concentration: > 100000 nM
Compound 4: a limit, no number (the forecaster's own chance of this, stated with the estimate: 10%); at least 5.0-fold (0.69 log units) between middle value and limit.
By their numbers in this assay, from the lowest: compounds 2, 3 and 1 (each within the scatter of the next). At a limit, above all of these: compound 4.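

Among these compounds, on this aromatic nitrogen, allyl in place of hydrogen gives the first step in the set that lies beyond the scatter: an at least 5.5-fold higher number from compound 2 to compound 4 (0.74 log units; beyond the scatter). The nitrogen is therefore not indifferent to what it carries, at least with the nitrile on the core. The value of compound 4 is a limit and not a number, so the step has no upper end: the limit of > 100000 nM in this assay, at which 1 of the 4 values shown sits.

The compounds shown leave open whether a methyl, a saturated propyl chain or a benzyl group on this nitrogen would act as allyl does. They also leave open whether allyl would have the same effect with the nitrile replaced by a thioamide.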